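Swapping the Outer Methyl for a Fluorine

This account rests on a few compounds, and the source may have more. Where it says the series, first, only, none or still open, it means among the compounds named here.

Of the compounds shown here, three sharing one core have been tested in a functional assay on MGC-803 cells (Homo sapiens) for inhibition, read by MTT assay, with a stated time of 48 h; a higher number here means a weaker inhibitor, a lower number a stronger inhibitor. Compound 1 `Cc1ccc(NC(=O)NC(=O)c2ccc(OCc3ccccc3)cc2)cc1-c1nc2ccccc2[nH]1` carries a plain benzyl ether and gives 39400 nM. Compound 2 `Cc1ccc(NC(=O)NC(=O)c2ccc(OCc3ccc(C(F)(F)F)cc3)cc2)cc1-c1nc2ccccc2[nH]1` adds a trifluoromethyl to that outer ring and gives 14900 nM. Compound 3 `Cc1ccc(COc2ccc(C(=O)NC(=O)Nc3ccc(C)c(-c4nc5ccccc5[nH]4)c3)cc2)cc1` carries a methyl there instead and gives 4250 nM, the lowest of the three and so the strongest inhibitor of this set: a 3.5-fold lower number from compound 2 to compound 3 (0.54 log units; beyond the scatter), and a 9.3-fold lower number from compound 1 to compound 3 (0.97 log units; beyond the scatter).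

Compound 4 `Cc1ccc(NC(=O)NC(=O)c2ccc(OCc3cccc(F)c3)cc2)cc1-c1nc2ccccc2[nH]1` is the next step from compound 3: 3-fluorophenyl in place of 4-methylphenyl on a saturated chain carbon bound to an oxygen on an aromatic ring. Among the compounds with values here, no measured step exchanges a methyl for a fluorine in this way, so the evidence is indirect. The step of a 9.3-fold lower number from compound 1 to compound 3 (0.97 log units; beyond the scatter) shows a modest gain when methyl replaces hydrogen on the outer ring, and a 2.6-fold lower number from compound 1 to compound 2 (0.42 log units; beyond the scatter) shows a smaller gain when trifluoromethyl does. Taking the methyl away would be expected to give back much of the first gain, while a single fluorine is a different substituent with no measured parallel here. A modest rise in this assay is therefore expected: a 3.5-fold higher number from compound 3 to compound 4 (0.55 log units; beyond the scatter). Compound 4 is estimated at 15000 nM, within a range from 5000 nM to 45000 nM.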

Compound 4, half-maximal inhibitory concentration: 44800 nM
Beside the measured number, compound 4's estimate is 3.0-fold (0.48 log units) below it; the measured number falls inside the stated range.
By their numbers in this assay, from the lowest: compound 3; then compound 2; then compounds 1 and 4 (each within the scatter of the next).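

Compound 4 shows that a substituent on the outer ring does not by itself lower the number, since 3-fluorophenyl in place of 4-methylphenyl gives an 11-fold higher number from compound 3 to compound 4 (1.02 log units; beyond the scatter), and in place of 4-(trifluoromethyl)phenyl it gives a 3.0-fold higher number from compound 2 to compound 4 (0.48 log units; beyond the scatter). Against the plain benzyl ether, fluoro in place of hydrogen gives a 1.1-fold higher number from compound 1 to compound 4 (0.06 log units; within the scatter), so in this assay this fluorine leaves the result level with the unsubstituted ring, unlike the methyl of compound 3 and the trifluoromethyl of compound 2. The change swaps both the group and its place on the ring, and nothing measured here explains the loss.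

On these data alone, what remains open is which of those two differences matters, a question that 4-fluorophenyl and 3-methylphenyl at this same position would help to settle. Also open, as far as these compounds go, is whether the gain seen with 4-methylphenyl extends to other groups in that place, such as 4-ethylphenyl or 4-methoxyphenyl.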